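The compounds below may be only part of what the source reports. "The series", "measured", "known", "first", "only" and "open" are said of these compounds alone.

Measured so far:
- compound 1 `CC(C)COC(=O)N1CCC(Oc2ncnc3c2CCN3c2ccc(S(C)(=O)=O)cc2F)CC1`: 94%
- compound 2 `CCSC(=O)N1CCC(Oc2ncnc3c2CCN3c2ccc(S(C)(=O)=O)cc2F)CC1`: 128%

Among the compounds with values here, in a functional assay on CHO-K1 cells with Glucose-dependent insulinotropic receptor (Homo sapiens) as the target, read by a luciferase reporter, with a stated time of 5 h (a lower number here means a smaller maximal response, a higher number a larger maximal response), compound 2 holds the higher of the two numbers, and its only neighbour is compound 1: a number 34 percentage points higher from compound 1 to compound 2 (beyond the scatter). That single step also frames the move to compound 3 `CC(C)c1noc(N2CCC(Oc3ncnc4c3CCN4c3ccc(S(C)(=O)=O)cc3F)CC2)n1`, which carries the change (3-isopropyl-1,2,4-oxadiazol-5-yl in place of (ethylsulfanyl)carbonyl on an amine nitrogen in a ring). Within the data shown here, the one measured step and this new one both alter the group on that ring nitrogen, but the measured step kept a carbonyl and swapped only the chain beside it, whereas here the whole carbonyl-bearing group gives way to an aromatic ring; no measured pair shows such a swap. What the data do show is that changing this group can shift the maximal response by a large amount, as a number 34 percentage points higher from compound 1 to compound 2 (beyond the scatter) did. A moderate step is therefore expected, most likely downward from the high value of compound 2, with wide uncertainty: a number 23 percentage points lower from compound 2 to compound 3 (beyond the scatter). Compound 3 is estimated at 105%, in a range from 65% to 145%.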

Compound 3, largest response reached (reported as percent of maximum), in percent of the reference or control that the assay uses: 124%
Estimate against measurement, compound 3: 19 percentage points below, and the stated range covers the measured number.
By their numbers in this assay, from the lowest: compound 1; then compounds 3 and 2 (each within the scatter of the next).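

In this assay, replacing the whole carbonyl-bearing group on the amine nitrogen in the ring with an aromatic ring gives a number 4 percentage points lower from compound 2 to compound 3 (within the scatter), so these two compounds do not separate. Set against the isobutoxycarbonyl group, the same swap gives a number 30 percentage points higher from compound 1 to compound 3 (beyond the scatter), which shows that, among these three compounds, a high maximal response at this position does not require a carbonyl attached to the nitrogen. Nothing given here offers a reason for either result.

The compounds shown leave open how much the isopropyl group on the 3-isopropyl-1,2,4-oxadiazol-5-yl ring matters, as a methyl or a tert-butyl group there would test. They also leave open how a simple acetyl group on the same ring nitrogen would compare.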